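A Second Trifluoromethyl Group on Compound 2

A few compounds are considered here, and "the series" means these few. Any claim that something is new, unique, unknown or untested is made for them only; others in the source may bear on it.

In a functional assay on VCaP cells (Homo sapiens) for antiproliferative activity, read by propidium iodide staining, with a stated time of 96 h (on this read-out higher numbers stand for weaker inhibition and lower numbers for stronger inhibition), compound 1 `CC(O)(CSc1cccc(S(F)(F)(F)(F)F)c1)C(=O)Nc1ccc(S(F)(F)(F)(F)F)cc1` gives 28200 nM and compound 2 `CC(O)(CSc1cccc(C(F)(F)F)c1)C(=O)Nc1ccc(S(F)(F)(F)(F)F)cc1` gives 18800 nM. Among the measured compounds shown here, these two numbers lie within the scatter of each other, so compound 2 stands level with the only other compound measured. Compound 3 `CC(O)(CSc1cc(C(F)(F)F)cc(C(F)(F)F)c1)C(=O)Nc1ccc(S(F)(F)(F)(F)F)cc1` has trifluoromethyl in place of hydrogen on an aromatic carbon, meta to a large group and meta to a trifluoromethyl group: trifluoromethyl in place of hydrogen on an aromatic carbon. For the measured compounds named here, only one measured step bears on this change, a 1.5-fold lower number from compound 1 to compound 2 (0.18 log units; within the scatter), and it stayed within the scatter. That step exchanged one group for another, whereas here a group replaces hydrogen, so it offers only indirect guidance. No step beyond the scatter is therefore expected in this assay, although the uncertainty is wide. The expected change is a 1.3-fold lower number from compound 2 to compound 3 (0.10 log units; within the scatter). The estimated value for compound 3 is 15000 nM, within an expected range of 5000 nM to 40000 nM.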

Compound 3, half-maximal inhibitory concentration: 19400 nM
Beside the measured number, compound 3's estimate is 1.3-fold (0.11 log units) below it; the measured number falls inside the stated range.
By their numbers in this assay, from the lowest: compounds 2, 3 and 1 (each within the scatter of the next).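

In this assay, trifluoromethyl in place of hydrogen on an aromatic carbon, meta to a large group and meta to a trifluoromethyl group, gives a 1.0-fold higher number from compound 2 to compound 3 (0.01 log units; within the scatter). The earlier step exchanged one group for another, whereas this one shows that adding a group of 4 heavy atoms where hydrogen stood produces no step beyond the scatter, so all three compounds now stand level with one another. Nothing measured here accounts for this flat result.

As far as these compounds go, it remains open whether a different group at this position, such as an amine, a carboxylic acid or a longer chain, would give a step beyond the scatter. From the compounds shown here alone, it is equally open whether a nitrile placed elsewhere on the shared core would do so.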